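Sulfonyl substituent swap: alkyl to amino at the terminal sulfur

A few compounds are considered here, and "the series" means these few. Any claim that something is new, unique, unknown or untested is made for them only; others in the source may bear on it.

Compound 3 `CCC(CC)S(=O)(=O)c1ccc(S(=O)(=O)N2CCC[C@@H](C(=O)N3CCN(c4nc(C(C)C)no4)CC3)C2)cc1` shows the lowest number of the three measured in a functional assay on MIA PaCa-2 cells (Homo sapiens) for inhibition, read by MTT assay, with a stated time of 7 days (on this read-out lower numbers stand for stronger inhibition and higher numbers for weaker inhibition), where compound 3 gives 50 nM. Compound 1 `CC(C)c1noc(N2CCN(C(=O)[C@@H]3CCCN(S(=O)(=O)c4ccc(S(=O)(=O)C(C)C)cc4)C3)CC2)n1` lies within the scatter of it: compound 1 gives 70 nM, and a 1.4-fold lower number from compound 1 to compound 3 (0.15 log units; within the scatter). Compound 2 `CC(C)c1noc(N2CCN(C(=O)[C@@H]3CCCN(S(=O)(=O)c4ccc(S(=O)(=O)NC5CC5)cc4)C3)CC2)n1` stands well apart, as compound 2 gives 1000 nM and a 20-fold lower number from compound 2 to compound 3 (1.30 log units; beyond the scatter). Compound 4 `CC(C)c1noc(N2CCN(C(=O)[C@@H]3CCCN(S(=O)(=O)c4ccc(S(=O)(=O)NC(C)(C)C)cc4)C3)CC2)n1` carries (tert-butyl)amino in place of pentan-3-yl on a sulfonyl sulfur. For the measured compounds named here, two measured steps bear on this exchange at the same sulfonyl sulfur: a 14-fold higher number from compound 1 to compound 2 (1.15 log units; beyond the scatter) and a 20-fold lower number from compound 2 to compound 3 (1.30 log units; beyond the scatter). Both were large and point the same way, so a large rise in the number is expected for compound 4 in this assay, a 14-fold higher number from compound 3 to compound 4 (1.15 log units; beyond the scatter). The estimate for compound 4 is 700 nM, with a range from 200 nM to 2500 nM.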

Compound 4, half-maximal inhibitory concentration: 300 nM
Compound 4: middle estimate off by 2.3-fold (0.37 log units), on the high side; the range from low to high includes it.
By their numbers in this assay, from the lowest: compounds 3 and 1 (each within the scatter of the next); then compound 4; then compound 2.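

In this assay, the group on the sulfonamide nitrogen matters: tert-butyl in place of cyclopropyl gives a modest fall in the number (a 3.3-fold lower number from compound 2 to compound 4 (0.52 log units; beyond the scatter)). The amino linkage at this sulfonyl sulfur is therefore not tied to a large rise, although compound 4 still stays behind both alkyl compounds (a 6.0-fold higher number from compound 3 to compound 4 (0.78 log units; beyond the scatter); a 4.3-fold higher number from compound 1 to compound 4 (0.63 log units; beyond the scatter)). No evidence on the cause of these steps is available here.

Still open, from the compounds shown here alone, is how an unsubstituted amino group or a dimethylamino group on this sulfonyl sulfur would read in this assay.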